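Trifluoromethoxy for trifluoromethyl on two cores

The compounds below may be only part of what the source reports. "The series", "measured", "known", "first", "only" and "open" are said of these compounds alone.

Compound 1 `CC(O)(CSc1ccc(C(F)(F)F)cc1)C(=O)Nc1cccc(S(F)(F)(F)(F)F)c1`; in a functional assay on LNCaP cells (Homo sapiens) for antiproliferative activity, read by propidium iodide staining, with a stated time of 96 h (a lower number here means a stronger inhibitor, a higher number a weaker inhibitor), compound 1 gives 17500 nM.
Compound 2 `CC(O)(CSc1ccc(OC(F)(F)F)cc1)C(=O)Nc1cccc(S(F)(F)(F)(F)F)c1`; in this assay compound 2 gives 10300 nM.
Compound 3 `CC(O)(COc1ccccc1C(F)(F)F)C(=O)Nc1ccc(S(F)(F)(F)(F)F)cc1`; in this assay compound 3 gives 1200 nM.

From compound 1 to compound 2 the change is trifluoromethoxy in place of trifluoromethyl on an aromatic carbon, and it made a 1.7-fold lower number from compound 1 to compound 2 (0.23 log units; within the scatter). Compound 3 stands on a different core; the difference between the two cores is not broken down here, and compound 3 holds the lowest of the measured numbers. Compound 4 `CC(O)(COc1ccccc1OC(F)(F)F)C(=O)Nc1ccc(S(F)(F)(F)(F)F)cc1` is not yet measured; it differs from compound 3 by trifluoromethoxy in place of trifluoromethyl on an aromatic carbon. This is the same kind of change as that from compound 1 to compound 2, not the same one: there the group sits para to a large group, here ortho to a large group. In this assay the expected step is a 1.3-fold lower number from compound 3 to compound 4 (0.12 log units; within the scatter), similar in size, since the earlier step of a 1.7-fold lower number from compound 1 to compound 2 (0.23 log units; within the scatter) stayed within the scatter. Compound 4 is estimated at 900 nM, with a range from 400 nM to 2500 nM.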

Compound 4, half-maximal inhibitory concentration: 8900 nM
Compound 4: the middle estimate sits 9.9-fold (1.00 log units) below what was measured, outside the stated range (above it).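

In this assay, trifluoromethoxy in place of trifluoromethyl on the core of compound 3 made a 7.4-fold higher number from compound 3 to compound 4 (0.87 log units; beyond the scatter). Within the data shown here, the result of this change on one core therefore did not hold on the other: the same change on two cores in this assay, a 1.7-fold lower number (0.23 log units; within the scatter) from compound 1 to compound 2 and a 7.4-fold higher number (0.87 log units; beyond the scatter) from compound 3 to compound 4, 13-fold (1.10 log units) apart, beyond the scatter of two such steps This shows that the step seen on the core of compound 1 cannot be read across to the core of compound 3, but with only two pairs it does not show which of the differences between them sets the steps apart.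

Open, as far as these compounds go, is whether the step follows the core or the place of the group, which a pair on the core of compound 1 with the group ortho to a large group would address. Also open, from the compounds shown here alone, is how a nitrile or a methoxy group at that place would stand on the core of compound 3.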